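The source may report more compounds than this note shows. Statements on the series, on what has been measured and on what is new or still open speak of the compounds shown alone.

Measured so far:
Compound 1 `c1cncc(-c2ccccc2OCC2=NCCN2)c1` — in a functional assay for activation of Alpha-1D adrenergic receptor (Homo sapiens), read by calcium flux (on this read-out lower numbers stand for an effect already at smaller amounts and higher numbers for an effect only at larger amounts of compound), compound 1 gives 158 nM.
Compound 2 `c1ccc(-c2ccncn2)c(OCC2=NCCN2)c1` — in this assay compound 2 gives only a limit, < 100000 nM.
Compound 3 `Cc1ccc(-c2ccccc2OCC2=NCCN2)s1` — in this assay compound 3 gives only a limit, < 100000 nM.

Compound 3 thus stands at the limit of this assay, not at a number; the same holds for compound 2, as the limit of < 100000 nM in this assay, at which 2 of the 3 values shown sit, sets out. Only compound 1 carries a read value.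

Compound 4 `Cc1cc(-c2ccccc2OCC2=NCCN2)sn1` is not yet measured. It differs from compound 3 in one place: 3-methyl-1,2-thiazol-5-yl in place of 5-methylthiophen-2-yl on an aromatic carbon.

Of the measured steps, the one that bears most directly on this change is a step that the limit leaves unreadable from compound 1 to compound 3, which is unreadable in size because of the limit; likewise a step that the two limits leave unreadable from compound 2 to compound 3 is unreadable with both ends at the limit. The only firm anchor is that compound 1 gives a number while compound 3 does not. For compound 4 the step that the limit leaves unreadable from compound 3 to compound 4 is therefore expected to be small or unreadable, with compound 4 likely to remain near the limit, though a return toward the range of compound 1 cannot be excluded. Compound 4 is estimated at 30000 nM, within 2000 nM to 100000 nM.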

Compound 4, half-maximal effective concentration: < 100000 nM
Compound 4 ended at the assay's limit (the forecaster's own chance of this, stated with the estimate: 50%); the middle value is on the limit's open side.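

In this assay compound 4 gives only a limit, < 100000 nM, and the steps linking compound 4 to compound 1, compound 2 and compound 3 cannot be read in size: the limit of < 100000 nM in this assay, at which 3 of the 4 values shown sit.

The compounds shown leave open how far compound 2, compound 3 and compound 4 lie from compound 1, and whether 3-methyl-1,2-thiazol-5-yl and 5-methylthiophen-2-yl differ at all on the shared core.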